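Imidazolyl for Cyclopentyl on a Poorly Soluble Core

This account rests on a few compounds, and the source may have more. Where it says the series, first, only, none or still open, it means among the compounds named here.

Compound 1 `Cc1ncc2c(N)c(C#N)c(N)nc2n1` carries a methyl group on the shared core and gives 783000 nM in a physicochemical assay for solubility, in phosphate buffer, with a stated time of 18 h; a higher number here means a more soluble compound, a lower number a less soluble compound. Compound 2 `CC(C)c1ncc2c(N)c(C#N)c(N)nc2n1` differs by isopropyl in place of methyl on an aromatic carbon. Its value in this assay is a limit of the assay: compound 2 gives > 1000000 nM, which is the limit of > 1000000 nM in this assay, at which 1 of the 3 values shown sits. The measured step of an at least 1.2-fold higher number from compound 1 to compound 2 (0.10 log units; that floor lies within the scatter) concerns alkyl size only. Compound 3 `CC(C)(C)c1nc(C2CCCC2)c2c(N)c(C#N)c(N)nc2n1` bears a tert-butyl group and a cyclopentyl group on the same core. In this assay compound 3 gives only a limit, < 1000 nM, which is the limit of < 1000 nM in this assay, at which 1 of the 3 values shown sits. It stands at the low end of the three values.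

Compound 4 `CC(C)(C)c1nc(-c2ncc[nH]2)c2c(N)c(C#N)c(N)nc2n1` differs from compound 3 in one place: 1H-imidazol-2-yl in place of cyclopentyl on an aromatic carbon. Among the measured compounds shown here, no measured step covers such a change; the sole measured step, an at least 1.2-fold higher number from compound 1 to compound 2 (0.10 log units; that floor lies within the scatter), offers no guide here. Because compound 3 sits at the limit of < 1000 nM in this assay, at which 1 of the 3 values shown sits, only an upward step can be read from its number. The step of an at least 3.0-fold higher number from compound 3 to compound 4 (0.47 log units; beyond the scatter) is expected to be modest and upward. Compound 4 is estimated at 3000 nM, within a range from 300 nM to 30000 nM.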

Compound 4, solubility: < 1000 nM
Compound 4: a limit, no number; the forecaster's own chance of this, stated with the estimate: 45%; middle value at least 3.0-fold (0.47 log units) from the limit.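

In this assay compound 4 gives < 1000 nM as a limit, so no step can be read between compound 3 and compound 4, since both stand at the same limit: the limit of < 1000 nM in this assay, at which 2 of the 4 values shown sit.

The compounds shown leave open whether 1H-imidazol-2-yl in place of cyclopentyl changes solubility at all, and by how much.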